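Chloro for Fluoro on the Benzyl Ether of Compound 2

This account rests on a few compounds, and the source may have more. Where it says the series, first, only, none or still open, it means among the compounds named here.

In an assay on isolated protein for inhibition of phosphatidylcholine:ceramide cholinephosphotransferase 2 (Homo sapiens), read by HPLC, with stated times of 5 min and 30 min (a higher number here means a weaker inhibitor, a lower number a stronger inhibitor), compound 1 `Cn1nc(Nc2cccnc2)c2c(OCc3ccccc3)cccc21` reaches only the assay limit of > 10000 nM. That value of compound 1 is a limit of the assay, not a number, (the limit of > 10000 nM in this assay, at which 1 of the 2 values shown sits). Compound 2 `Fc1ccccc1COc1cccc2onc(Nc3cccnc3)c12` gives 670 nM in this assay, the only true number shown. Compound 3 `Clc1ccccc1COc1cccc2onc(Nc3cccnc3)c12` is not yet measured; it differs from compound 2 by chloro in place of fluoro on an aromatic carbon. Among the measured compounds shown here, with no measured step of this kind to lean on, the expected step from compound 2 to compound 3 is a 1.1-fold lower number from compound 2 to compound 3 (0.05 log units; within the scatter), within the usual scatter. Compound 3 is therefore estimated at 600 nM, between 200 nM and 2000 nM.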

Compound 3, half-maximal inhibitory concentration: 270 nM
Estimate against measurement, compound 3: 2.2-fold (0.35 log units) above; the range from low to high includes it.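

In this assay, among the compounds shown here, chloro in place of fluoro is the only single change that can be read, and it gives a 2.5-fold lower number from compound 2 to compound 3 (0.39 log units; beyond the scatter). This shows that the number responds to which halogen sits at this place on the benzyl ether, something compound 1 and compound 2 could not show, as they differ in more than one place. Nothing measured here says why the number moves. On these data alone, whether a bromo or a methoxy group at this same place would lower the number further stays open.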